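The compounds below may be only part of what the source reports. "The series", "measured", "known", "first", "only" and "open" are said of these compounds alone.

Measured so far in a functional assay on HepG2 cells (Homo sapiens) for cytotoxicity, read by colorimetric assay and neutral red uptake, with a stated time of 72 h (a lower number here means a stronger inhibitor, a higher number a weaker inhibitor), are two compounds.
- Compound 1 `CO[C@@H](C(=O)N[C@@H]1CCCCNC1=O)[C@H](O)[C@@H](O)[C@H](O)/C=C/C(C)(C)C` gives 1100 nM here
- Compound 2 `CO[C@@H](C(=O)N[C@@H]1CC[C@@H](O)CNC1=O)[C@H](O)[C@@H](O)[C@H](O)/C=C/C(C)(C)C` gives 21300 nM here

Compound 2, at 21300 nM here, has the higher of the two numbers and is the weaker inhibitor of the pair. Compound 3 `CO[C@@H](C(=O)N[C@@H]1CC[C@H](O)CNC1=O)[C@H](O)[C@@H](O)[C@H](O)/C=C/C(C)(C)C` has the same atoms and bonds as compound 2 and differs only in configuration as drawn, with the two compounds have the same atoms and bonds and differ only in configuration as drawn: 1 of 7 stereo elements differ; a stereocentre at a saturated ring carbon is drawn R in compound 2 and S in compound 3 and a stereocentre at a saturated ring carbon drawn R in compound 2 and S in compound 3.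

Within the data shown here, one measured step bears on this change. Placing hydroxy in place of hydrogen on a saturated ring carbon gave a large step, a 19-fold higher number from compound 1 to compound 2 (1.29 log units; beyond the scatter) in this series. Among the measured compounds shown here, no measured step tests configuration at that carbon, so the direction remains uncertain. Compound 3 keeps the hydroxy, so a partial return toward compound 1 is expected rather than a full one. The expected move is a 2.4-fold lower number from compound 2 to compound 3 (0.37 log units; beyond the scatter) in this assay and is smaller than the step just described. For compound 3 the estimated value is 9000 nM with an expected range from 1800 nM to 40000 nM in this assay.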

Compound 3, half-maximal inhibitory concentration: 138000 nM
Compound 3: the middle estimate sits 15-fold (1.19 log units) below what was measured; the whole stated range lies below it.
By their numbers in this assay, from the lowest: compound 1; then compound 2; then compound 3.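

In this assay, the drawn configuration at the saturated ring carbon carrying the hydroxy matters as well as the presence of the hydroxy: changing it from R to S gives a 6.5-fold higher number from compound 2 to compound 3 (0.81 log units; beyond the scatter). Hydroxy in place of hydrogen on a saturated ring carbon now has two readings in the same direction, a 19-fold higher number from compound 1 to compound 2 (1.29 log units; beyond the scatter) for the R form and a 130-fold higher number from compound 1 to compound 3 (2.10 log units; beyond the scatter) for the S form, so the size of this change depends on the configuration at that carbon. The separation between the two hydroxy compounds can be assigned to stereochemistry alone: the fact that compounds 2 and 3 differ only in the configuration as drawn.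

The compounds shown leave open whether the rise in number belongs to the hydroxy itself or would follow from other groups on that ring carbon, such as a methoxy group, an amine or a fluorine atom. They also leave open whether the S form would again carry the higher number with any such group in place of the hydroxy.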